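Amide aryl swap on the shared core: lipophilicity notes

The source may hold more compounds than are shown below. What is called first, only, known or untested is meant among the compounds shown, and "the series" means these compounds.

Compound 2 `C[C@@]1(c2cc(NC(=O)c3cnc(OCF)cn3)ccc2F)C=C(CF)OC(N)=N1` stands second highest of the three numbers in a physicochemical assay for lipophilicity, read by HPLC, in phosphate buffer, measured as octanol-water partition, with a stated time of 1 h, at pH 7.4 (on this read-out lower numbers stand for lower lipophilicity and higher numbers for higher lipophilicity), where compound 2 gives 2.6. Compound 3 `C[C@@]1(c2cc(NC(=O)c3ncc(OCF)nc3N)ccc2F)C=C(CF)OC(N)=N1` gives 3.1 in this assay, reached by a number 0.50 log units higher from compound 2 to compound 3 (beyond the scatter). Among the measured compounds shown here, compound 1 `COCC1=C[C@@](C)(c2cc(NC(=O)c3ccc(C#N)cn3)ccc2F)N=C(N)O1` gives 2 in this assay; no single-point step joins it to compound 2, so the two values are only set side by side. Compound 4 `COc1cc(C#N)cnc1C(=O)Nc1ccc(F)c([C@]2(C)C=C(CF)OC(N)=N2)c1` differs from compound 2 by 5-cyano-3-methoxypyridin-2-yl in place of 5-(fluoromethoxy)pyrazin-2-yl on a carbonyl carbon. For the measured compounds named here, no measured step covers this exchange; the one step recorded, amino in place of hydrogen, was modest. A step downward is expected, a number 0.20 log units lower from compound 2 to compound 4 (within the scatter), because compound 1 with its nitrile-bearing amide gives 2. Compound 4 is estimated at 2.4, within 1.9 to 2.9.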

Compound 4, distribution coefficient: 1.9
Compound 4: the middle estimate sits 0.50 log units above what was measured; low and high end bracket the measured number.
By their numbers in this assay, from the lowest: compounds 4 and 1 (each within the scatter of the next); then compound 2; then compound 3.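

On a carbonyl carbon whose other neighbours are amide-type nitrogen, 5-cyano-3-methoxypyridin-2-yl in place of 5-(fluoromethoxy)pyrazin-2-yl moves this assay downward, with a number 0.70 log units lower from compound 2 to compound 4 (beyond the scatter) in this exchange of the whole aryl group. In place of 3-amino-5-(fluoromethoxy)pyrazin-2-yl, the same group gives a number 1.20 log units lower from compound 3 to compound 4 (beyond the scatter), the largest step recorded in the series. No measured data explain these steps.

Going by these compounds, the nitrile, the methoxy and the change in ring hetero atoms enter together, so their shares remain open. A 5-cyanopyrazin-2-yl group on this carbonyl carbon would separate the ring change from the methoxy.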